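Compound 3: methyl in place of methoxy

The source may report more compounds than this note shows. Statements on the series, on what has been measured and on what is new or still open speak of the compounds shown alone.

In a physicochemical assay for solubility, at pH 1.1 (a lower number here means a less soluble compound, a higher number a more soluble compound), compound 1 (`COc1cc(CN(CC(C)C)C(CC(=O)O)c2ccc3c(c2)CCO3)ccc1OCCN1C(=O)CCC1=O`) gives 3000000 nM and compound 2 (`COc1cc(CN(CC(C)C)C(CC(=O)O)c2ccc(Cl)cc2Cl)ccc1OCCN1C(=O)CCC1=O`) gives 3000000 nM while compound 3 (`COc1cc(CN(CC(C)C)C(CC(=O)O)c2ccc(Cl)c(F)c2)ccc1OCCN1C(=O)CCC1=O`) gives 3000000 nM and so stands level with both. Compound 4 (`Cc1cc(CN(CC(C)C)C(CC(=O)O)c2ccc(Cl)c(F)c2)ccc1OCCN1C(=O)CCC1=O`) has methyl in place of methoxy on an aromatic carbon. Among the measured compounds shown here, no measured step touches this position. The steps available change only the aromatic group on the saturated chain carbon, and they show no change at the digits printed from compound 1 to compound 2 (within the scatter) then no change at the digits printed from compound 1 to compound 3 (within the scatter) then no change at the digits printed from compound 2 to compound 3 (within the scatter) and so bear on the change only indirectly. In this assay the expected step is no change at the digits printed from compound 3 to compound 4 (within the scatter) and none beyond the scatter is expected. Compound 4 is estimated at 3000000 nM with an expected range from 1500000 nM to 3500000 nM in this read-out.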

Compound 4, solubility: 3000000 nM
Beside the measured number, compound 4's estimate shows no gap at the digits printed; low and high end bracket the measured number.
By their numbers in this assay, from the lowest: compounds 1, 2, 3 and 4 (each within the scatter of the next).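

In this assay, among the compounds shown here, the step of no change at the digits printed from compound 3 to compound 4 (within the scatter) is the first reading at this position, as the earlier steps changed only the aromatic group on the saturated chain carbon. On the aromatic carbon ortho to the 2-(2,5-dioxopyrrolidin-1-yl)ethoxy group, this pair shows that methoxy and its hydrogen-bond acceptor can give way to methyl with the read-out unmoved. No measured evidence accounts for this result. Still open, going by these compounds, is whether a primary amine or an ethoxy group at this aromatic carbon would hold the same value in this assay as well.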